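This account rests on a few compounds, and the source may have more. Where it says the series, first, only, none or still open, it means among the compounds named here.

In a functional assay on HT-29 cells (Homo sapiens) for inhibition, read by MTT assay, with a stated time of 48 h (a lower number here means a stronger inhibitor, a higher number a weaker inhibitor), compound 1 `COc1ccc(-n2c(SCc3ccccc3)nnc2-c2cc(OC)c(OC)c(OC)c2)cc1` gives > 60000 nM, which is a limit. Compound 2 `COc1ccc(CSc2nnc(-c3cc(OC)c(OC)c(OC)c3)n2-c2ccc(OC)cc2)cc1` gives > 60000 nM, also a limit, and so stands at the limit of > 60000 nM in this assay, at which 2 of the 3 values shown sit. Compound 3 `COc1ccc(NC(=O)CSc2nnc(-c3cc(OC)c(OC)c(OC)c3)n2-c2ccc(OC)cc2)cc1` gives 45300 nM. Compound 4 `COc1ccc(CSc2nnc(-c3cc(OC)c(OC)c(OC)c3)n2-c2ccc(N(C)C)cc2)cc1` carries dimethylamino in place of methoxy on an aromatic carbon, para to a large group: dimethylamino in place of methoxy on an aromatic carbon. Among the measured compounds shown here, no measured step makes this change. The nearest are a step that the two limits leave unreadable from compound 1 to compound 2, then an at least 1.3-fold lower number from compound 1 to compound 3 (0.12 log units; that floor lies within the scatter), and an at least 1.3-fold lower number from compound 2 to compound 3 (0.12 log units; that floor lies within the scatter); the last two have floors within the scatter. These steps give no size for the change, so only a modest shift toward a lower number is expected in this assay. The expected step is an at least 1.5-fold lower number from compound 2 to compound 4 (0.17 log units; that floor lies within the scatter). For compound 4 the estimated value is 40000 nM, with an expected range from 8000 nM to 90000 nM.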

Compound 4, half-maximal inhibitory concentration: > 60000 nM
Compound 4 gave a limit, no number; the forecaster's own chance of this, stated with the estimate: 50%; middle value at least 1.5-fold (0.17 log units) away from the limit.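

Compound 2 and compound 4 both give only a limit in this assay, so the step between them cannot be read: the limit of > 60000 nM in this assay, at which 3 of the 4 values shown sit. Going by these compounds, what dimethylamino in place of methoxy does to inhibition stays open.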